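A Methyl Next to the Ring Nitrogen, Twice

The source may report more compounds than this note shows. Statements on the series, on what has been measured and on what is new or still open speak of the compounds shown alone.

Measured compounds:
compound 1 `Oc1cc(-c2ccc3ccccc3c2)nc2ncccc12` 9120 nM
compound 2 `Cc1ccnc2nc(-c3cccc4ccccc34)cc(O)c12` 10.7 nM
compound 3 `Cc1cc(C)c2c(O)cc(-c3cccc4ccccc34)nc2n1` 589 nM

In a functional assay on SF-295 cells (Homo sapiens) for antiproliferative activity (a lower number here means a stronger inhibitor of growth, a higher number a weaker inhibitor of growth), compound 2 gives 10.7 nM, while compound 3 gives 589 nM. The change between them is methyl in place of hydrogen on an aromatic carbon, and it made a 55-fold higher number from compound 2 to compound 3 (1.74 log units; beyond the scatter). Compound 1 gives 9120 nM in this assay; how its core differs from that of compound 2 is not broken down here, and the two values simply show compound 1 far weaker.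

Compound 4 `Cc1ccc2c(O)cc(-c3ccc4ccccc4c3)nc2n1` is not yet measured. It arises from compound 1 by methyl in place of hydrogen on an aromatic carbon. Within the data shown here, this is the same kind of change as the one from compound 2 to compound 3, though the surroundings differ: in compound 3 the new methyl is also meta to a methyl group, and compound 1 has no such group. Among the measured compounds shown here, only one measured example of this change exists, so the expectation rests on it alone. Compound 4 is expected to be weaker than compound 1 in this assay, with a step of about a 3.3-fold higher number from compound 1 to compound 4 (0.52 log units; beyond the scatter), because the same change gave a 55-fold higher number from compound 2 to compound 3 (1.74 log units; beyond the scatter). The estimate for compound 4 is 30000 nM, somewhere between 6000 nM and 150000 nM, and a limit rather than a number is quite possible.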

Compound 4, concentration for 50% growth inhibition: 3800 nM
Compound 4: middle estimate off by 7.9-fold (0.90 log units), on the high side, and the stated range ends above it.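

In this assay, putting a methyl on the aromatic carbon next to the ring nitrogen gave a 2.4-fold lower number from compound 1 to compound 4 (0.38 log units; beyond the scatter), a modest gain in growth inhibition on this core. The same swap of hydrogen for methyl therefore does not carry over unchanged from one core to another in this series, and even its direction differs between the two cases: the same change on two cores in this assay, a 55-fold higher number (1.74 log units; beyond the scatter) from compound 2 to compound 3 and a 2.4-fold lower number (0.38 log units; beyond the scatter) from compound 1 to compound 4, 130-fold (2.12 log units) apart, beyond the scatter of two such steps These two pairs do not show why the steps part ways: the two cores differ from each other in more than one place, and two pairs give no rule for predicting the step on a third core.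

The compounds shown leave open whether a larger group on this same carbon, such as an ethyl or a methoxy group, would follow the small gain seen with compound 4 or the large loss seen with compound 3. They also leave open how an amine or a chlorine atom at that carbon would fare on either core.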